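The source may report more compounds than this note shows. Statements on the series, on what has been measured and on what is new or still open speak of the compounds shown alone.

Working notes on the series. In a physicochemical assay for solubility (a lower number here means a less soluble compound, a higher number a more soluble compound), compound 3 (`CC(C)COc1cc(C(F)(F)F)nn1-c1ccc(S(C)(=O)=O)cn1`) gives 50 ug/mL and compound 1 (`CC1CCCN(c2c(C#N)c(C(F)(F)F)nn2-c2ccc(S(C)(=O)=O)cn2)C1`) gives 100 ug/mL. Among the compounds with values here, these two values lie within the scatter of each other, so compound 3 stands level with the only other number available. In this assay compound 2 (`CS(=O)(=O)c1ccc(-n2nc(C(F)(F)F)c(C#N)c2NC2CCC2)nc1`) stands as "not determined" (no result reported) and adds nothing here.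

Compound 4 (`CC(C)COc1c(C#N)c(C(F)(F)F)nn1-c1ccc(S(C)(=O)=O)cn1`) differs from compound 3 by cyano in place of hydrogen on an aromatic carbon.

Within the data shown here, no two measured compounds differ in one place only, so no direct measure of this change exists. The nearest evidence is compound 1, which carries the cyano with a different group in place of isobutoxy and gives 100 ug/mL. That value offers no sign of a large change, and no step beyond the scatter is expected in this assay. The expected change is a 1.1-fold lower number from compound 3 to compound 4 (0.05 log units; within the scatter), with the direction left open. For compound 4 the estimated value is 45 ug/mL, with an expected range of 18 ug/mL to 110 ug/mL.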

Compound 4, solubility: < 25 ug/mL
Compound 4 gave a limit, no number; the forecaster's own chance of this, stated with the estimate: 15%; at least 1.8-fold (0.25 log units) between middle value and limit.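

In this assay compound 4 gives < 25 ug/mL, which is a limit of the assay and not a number. At this position, on an aromatic carbon next to the ring atom that bears a trifluoromethyl group, cyano in place of hydrogen gives an at least 2.0-fold lower number from compound 3 to compound 4 (0.30 log units; that floor lies within the scatter), so the floor of this change does not clear the scatter, though the full step may be larger. Within the data shown here, with the cyano held in place, isobutoxy in place of 3-methylpiperidin-1-yl gives an at least 4.0-fold lower number from compound 1 to compound 4 (0.60 log units; beyond the scatter), the first step to clear the scatter.

As far as these compounds go, the true size of both steps stays open, as compound 4 has only a limit: the limit of < 25 ug/mL in this assay, at which 1 of the 4 values shown sits. Also open is how a carboxylic acid or a longer alkoxy chain in place of isobutoxy would read with the cyano kept.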